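The source may report more compounds than this note shows. Statements on the series, on what has been measured and on what is new or still open speak of the compounds shown alone.

Measured so far:
Compound 1 `C/C(C#Cc1ccccc1)=N\N/C(N)=N/S(=O)(=O)c1cc(C)c(Cl)cc1SCc1ccccc1`: in a functional assay on HeLa cells (Homo sapiens) for antiproliferative activity, read by MTT assay, with a stated time of 72 h (on this read-out lower numbers stand for stronger inhibition and higher numbers for weaker inhibition), compound 1 gives 6000 nM.
Compound 2 `C/C(C#Cc1ccccc1)=N\N/C(N)=N/S(=O)(=O)c1cc(C)c(Cl)cc1SCc1ccccc1C`: compound 2 gives 270000 nM.
Compound 3 `C/C(C#Cc1ccccc1)=N\N/C(N)=N/S(=O)(=O)c1cc(C)c(Cl)cc1SCc1cccc(C)c1`: compound 3 gives 105000 nM.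

Compound 3 holds the second highest of the three numbers: an 18-fold higher number from compound 1 to compound 3 (1.24 log units; beyond the scatter), while a 2.6-fold lower number from compound 2 to compound 3 (0.41 log units; beyond the scatter).

Compound 4 `C/C(C#Cc1ccccc1)=N\N/C(N)=N/S(=O)(=O)c1cc(C)c(Cl)cc1SCc1cccc(C(F)(F)F)c1` differs from compound 3 by trifluoromethyl in place of methyl on an aromatic carbon, on an aromatic carbon of a six-membered aromatic ring of carbon only, meta to a large group. For the measured compounds named here, no measured step swaps methyl for trifluoromethyl. The steps that touch this position show that adding methyl there costs much: an 18-fold higher number from compound 1 to compound 3 (1.24 log units; beyond the scatter) and a 45-fold higher number from compound 1 to compound 2 (1.65 log units; beyond the scatter). A substituent of this kind at this place is thus already present in compound 3, and the further change is expected to give no step beyond the scatter, a 1.1-fold higher number from compound 3 to compound 4 (0.06 log units; within the scatter).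

Compound 4 is estimated at 120000 nM, range 40000 nM to 350000 nM.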

Compound 4, half-maximal inhibitory concentration: 18000 nM
Estimate against measurement, compound 4: 6.7-fold (0.82 log units) above; the whole stated range lies above it.
By their numbers in this assay, from the lowest: compound 1; then compound 4; then compound 3; then compound 2.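

At this place the identity of the substituent matters, not just its presence: trifluoromethyl gives a clear gain over methyl (a 5.8-fold lower number from compound 3 to compound 4 (0.77 log units; beyond the scatter)) and a larger one against compound 2 (a 15-fold lower number from compound 2 to compound 4 (1.18 log units; beyond the scatter)). Hydrogen still stays ahead of trifluoromethyl (a 3.0-fold higher number from compound 1 to compound 4 (0.48 log units; beyond the scatter)), so no substituent shown here improves on compound 1. Nothing at hand accounts for the gap between methyl and trifluoromethyl.

Open, going by these compounds, is whether a chlorine, a methoxy group or an amine at this place would match hydrogen. Also open, on these data alone, is how 2-(trifluoromethyl)benzyl compares with 3-(trifluoromethyl)benzyl.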